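The compounds below may be only part of what the source reports. "The series", "measured", "known", "first", "only" and "open" are said of these compounds alone.

Working notes on the series, starting from compound 1 `COc1cc(/C=C/C(=O)C2=C(/C=C/c3ccc(O)c(OC)c3)NC(=O)NC2c2ccccc2)ccc1O`. In a functional assay on HeLa cells (Homo sapiens) for cytotoxicity, read by MTT assay, with a stated time of 48 h (on this read-out lower numbers stand for stronger inhibition and higher numbers for weaker inhibition), compound 1 gives 100000 nM. Among the compounds with values here, compound 2 `COc1cc(/C=C/C(=O)C2=C(/C=C/c3ccc(O)c(OC)c3)NC(=O)NC2c2c(Cl)cccc2Cl)ccc1O` gives 25000 nM, the lower of the two numbers so far. Next in line is compound 3 `COc1cc(/C=C/C(=O)C2=C(/C=C/c3ccc(O)c(OC)c3)NC(=O)NC2c2cccc([N+](=O)[O-])c2)ccc1O`, which differs by 3-nitrophenyl in place of 2,6-dichlorophenyl on a saturated ring carbon. Within the data shown here, only one measured step bears on this, the modest 4.0-fold lower number from compound 1 to compound 2 (0.60 log units; beyond the scatter), which lies beyond the scatter and came with 2,6-dichlorophenyl in place of phenyl. Among the measured compounds shown here, no measured compound carries 3-nitrophenyl, so that step gives only weak guidance. In this assay a small move towards a higher number is expected, probably not clearly beyond the scatter. The estimated step is a 1.6-fold higher number from compound 2 to compound 3 (0.20 log units; within the scatter). Compound 3 is expected at 40000 nM, with an estimated range from 13000 nM to 100000 nM.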

Compound 3, half-maximal inhibitory concentration: 100000 nM
The estimate for compound 3 lay 2.5-fold (0.40 log units) below the measured number; the measured number falls inside the stated range.
By their numbers in this assay, from the lowest: compound 2; then compounds 1 and 3 (each within the scatter of the next).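

In this assay, 3-nitrophenyl in place of 2,6-dichlorophenyl on the saturated ring carbon gives a 4.0-fold higher number from compound 2 to compound 3 (0.60 log units; beyond the scatter) and so shows that the lower number of compound 2 does not carry over to every substituted phenyl at this position. Nitro in place of hydrogen on an aromatic carbon gives no change at the digits printed from compound 1 to compound 3 (within the scatter) and leaves compound 1 and compound 3 indistinguishable, so among these three compounds only the 2,6-dichlorophenyl group stands apart. No measurement on hand accounts for this difference.

The compounds shown leave open whether a single chlorine on the phenyl ring would match the 2,6-dichlorophenyl group or whether both chlorines are needed. They also leave open whether an amine or a carboxylic acid on that ring would move the number at all.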